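A few compounds are considered here, and "the series" means these few. Any claim that something is new, unique, unknown or untested is made for them only; others in the source may bear on it.

Compound 1, `CC(C)c1cccc(C(C)C)c1NC(=O)NS(=O)(=O)N(C)C`, is tested in an assay on liver for inhibition of sterol O-acyltransferase 1 (Rattus norvegicus), using microsomes (a lower number here means a stronger inhibitor, a higher number a weaker inhibitor), where compound 1 gives 3900 nM. Among the two numbers measured so far this is the highest; the nearest is compound 2, `C=CCN(CC)S(=O)(=O)NC(=O)Nc1c(C(C)C)cccc1C(C)C`, which in this assay gives 2100 nM. Within the data shown here, the only measured step between these two, a 1.9-fold lower number from compound 1 to compound 2 (0.27 log units; within the scatter), lies within the scatter, so neither compound can be called the stronger inhibitor on this evidence.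

The step now followed leads to compound 3, `CC(C)CN(CC(C)C)S(=O)(=O)NC(=O)Nc1c(C(C)C)cccc1C(C)C`, whose difference from compound 1 is diisobutylamino in place of dimethylamino on a sulfonyl sulfur. Among the measured compounds shown here, the one measured step that bears on this change is a 1.9-fold lower number from compound 1 to compound 2 (0.27 log units; within the scatter), since it too exchanges the dimethylamino on the sulfonyl sulfur for another amino group, and it stayed within the scatter. With a single step of that size to go on, the expectation for compound 3 in this assay is a number that may sit somewhat lower than that of compound 1 but most likely not far beyond the scatter, a step of about a 2.6-fold lower number from compound 1 to compound 3 (0.41 log units; beyond the scatter). Compound 3 is therefore estimated at 1500 nM, with a range from 450 nM to 5000 nM.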

Compound 3, half-maximal inhibitory concentration: 420 nM
The estimate for compound 3 lay 3.6-fold (0.55 log units) above the measured number, and the stated range ends above it.
By their numbers in this assay, from the lowest: compound 3; then compounds 2 and 1 (each within the scatter of the next).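

At the amino group on the sulfonyl sulfur, the earlier pair had shown no change that could be read in this assay, but diisobutylamino in place of dimethylamino gives a 9.3-fold lower number from compound 1 to compound 3 (0.97 log units; beyond the scatter), so exchanging the amino group at this place can move the number beyond the scatter. Diisobutylamino also stands apart from allyl(ethyl)amino, with a 5.0-fold lower number from compound 2 to compound 3 (0.70 log units; beyond the scatter), which shows that the result depends on which amino group enters: compound 2 goes against any reading that all replacements of dimethylamino give a clear drop, and compound 3 now has the lowest number of the three. Nothing given here accounts for this difference between the amino groups.

The three compounds leave open whether the branching of the isobutyl chains matters or whether a straight chain, such as in dibutylamino, would give a number like that of compound 3. They also leave open how a ring amine such as piperidine, or an amino group carrying a phenyl ring or a carboxylic acid, would behave at this place on the sulfonyl sulfur.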